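Fluoro for methoxy in the nitro series

The compounds below may be only part of what the source reports. "The series", "measured", "known", "first", "only" and "open" are said of these compounds alone.

compound 1 `COc1cc(OC)c(/C=C/S(=O)(=O)Nc2ccc(F)c(N)c2)c(OC)c1` 10000 nM
compound 2 `COc1cc(OC)c(/C=C/S(=O)(=O)Nc2ccc(OC)c([N+](=O)[O-])c2)c(OC)c1` 2500 nM

In a functional assay on DU-145 cells (Homo sapiens) for cytotoxicity, read by trypan blue exclusion, with a stated time of 96 h (on this read-out lower numbers stand for stronger inhibition and higher numbers for weaker inhibition), compound 2 holds the lower of the two numbers, and compound 1 lies higher, beyond the scatter. Compound 3 `COc1cc(OC)c(/C=C/S(=O)(=O)Nc2ccc(F)c([N+](=O)[O-])c2)c(OC)c1` is still unmeasured and has fluoro in place of methoxy on an aromatic carbon, ortho to a nitro group and para to a large group fluoro in place of methoxy on an aromatic carbon in comparison with compound 2. Among the compounds with values here, no measured step isolates this change. Compound 1 also carries fluoro and gives 10000 nM in the same test, so a small shift toward weaker inhibition, probably within the scatter, is expected. The estimated step is modest (a 1.6-fold higher number from compound 2 to compound 3 (0.20 log units; within the scatter)). For compound 3 the estimated value is 4000 nM (expected range 1000 nM to 15000 nM).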

Compound 3, half-maximal inhibitory concentration: 100000 nM
Estimate against measurement, compound 3: 25-fold (1.40 log units) below; the whole stated range lies below it.
By their numbers in this assay, from the lowest: compound 2; then compound 1; then compound 3.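

In this assay, the place ortho to a nitro group is far from indifferent to this exchange: fluoro in place of methoxy gives a 40-fold higher number from compound 2 to compound 3 (1.60 log units; beyond the scatter) and is no minor edit. With fluoro held fixed, nitro in place of amino on an aromatic carbon gives a 10-fold higher number from compound 1 to compound 3 (1.00 log units; beyond the scatter) as well, so the result depends on the nitro or amino group too. No measurement here explains either step.

On these data alone, whether the fluoro and nitro pairing alone carries this shift remains open. Hydroxyl or chloro at this place, set against the same nitro group, would help to separate these readings.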